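Swapping bromo for fluoro on a weak antiproliferative

A few compounds are considered here, and "the series" means these few. Any claim that something is new, unique, unknown or untested is made for them only; others in the source may bear on it.

compound 1 `S=C(N/N=C/c1ccc2ccccc2n1)Nc1cccc(Br)c1` — 58900 nM
compound 2 `Cc1ccc(NC(=O)N/N=C/c2ccc3ccccc3n2)cc1` — > 100000 nM

In a functional assay on HT-29 cells (Homo sapiens) for antiproliferative activity, read by sulforhodamine B assay, with a stated time of 72 h (a higher number here means a weaker inhibitor, a lower number a stronger inhibitor), compound 1 gives 58900 nM. Among the measured compounds shown here, that is the only number measured in this small set, and it marks compound 1 as a weak inhibitor. For compound 2 the result is not a number but a limit, > 100000 nM, meaning the assay reports only (the limit of > 100000 nM in this assay, at which 1 of the 2 values shown sits).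

Compound 3 `Fc1cccc(NC(=S)N/N=C/c2ccc3ccccc3n2)c1` has not yet been measured. It differs from compound 1 in one place: fluoro in place of bromo on an aromatic carbon. For the measured compounds named here, no step between two measured compounds has been recorded, so there is nothing to calibrate this swap against, and the expectation rests on compound 1 alone. The step from compound 1 to compound 3 is expected to be a 1.2-fold higher number from compound 1 to compound 3 (0.07 log units; within the scatter), a shift that stays within the usual scatter. Compound 3 is therefore expected to give about 70000 nM in this assay, most likely between 25000 nM and 200000 nM.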

Compound 3, half-maximal inhibitory concentration: 74700 nM
Compound 3: the middle estimate sits 1.1-fold (0.03 log units) below what was measured, within the range that was stated.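

In this assay, fluoro in place of bromo on this aromatic carbon gives a 1.3-fold higher number from compound 1 to compound 3 (0.10 log units; within the scatter). Among the compounds shown here, this is the first step in the set that can be read, and it shows that, for this pair, the 3-bromophenyl and 3-fluorophenyl groups cannot be told apart, with both compounds remaining weak inhibitors. Nothing measured here gives a reason for this result.

Going by these compounds, a swap between two halogens tests only a narrow change, so it remains open whether any group at this position can move the number beyond the scatter. An amine, a methoxy group or a carboxylic acid in place of the halogen would test this more widely, and the same position on the ring could then be compared across a broader range of groups.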